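A fluoro swap on a compound at the assay limit

This account rests on a few compounds, and the source may have more. Where it says the series, first, only, none or still open, it means among the compounds named here.

Of the compounds shown here, three sharing one core have been tested in an ADME assay on DU-145 cells (Homo sapiens) for cytotoxicity, read by MTT assay, with a stated time of 72 h; a lower number here means a stronger inhibitor, a higher number a weaker inhibitor. Compound 1 `COc1ccc(C2=C(c3cc(OC)c(OC)c(OC)c3)C(=O)CC2O[SiH2]C(C)(C)C)cc1` gives > 100 ug/mL, which is a limit of the assay and not a number. Compound 2 `COc1ccc(C2=C(c3cc(OC)c(OC)c(OC)c3)C(=O)C(O)C2)cc1NC(=O)c1ccccc1` gives > 100 ug/mL, again a limit. Compound 3 `COc1cc(C2=C(c3cc(C)c(OC)c(C)c3)C(OC(C)=O)CC2=O)cc(OC)c1OC` gives > 100 ug/mL, also a limit. Compound 2 therefore has no rank of its own among them, as the record shows (the limit of > 100 ug/mL in this assay, at which 3 of the 3 values shown sit). Going by the values given here, no measured pair differs in a single place, so the data show no size for any one structural change.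

Compound 4 `COc1ccc(C2=C(c3cc(OC)c(OC)c(OC)c3)C(=O)C(O)C2)cc1F` has not yet been measured. It differs from compound 2 in one place, with fluoro in place of benzamido on an aromatic carbon, ortho to a methoxy group and meta to a large group: fluoro in place of benzamido on an aromatic carbon.

In this assay the expected direction is toward stronger inhibition, since compound 2 sits at > 100 ug/mL, a limit. The expected size is moderate and uncertain, and another result at the limit remains quite possible. The estimated change is an at least 3.3-fold lower number from compound 2 to compound 4 (0.52 log units; beyond the scatter). Compound 4 is estimated at 30 ug/mL, with an expected range from 2 ug/mL to 100 ug/mL.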

Compound 4, half-maximal inhibitory concentration: 27 ug/mL
For compound 4 the middle estimate is 1.1-fold (0.05 log units) above the measured one; measured number inside the range.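

In this assay, the exchange of benzamido for fluoro on the aromatic carbon, ortho to a methoxy group and meta to a large group, gives the only readable step among the compounds shown: an at least 3.7-fold lower number from compound 2 to compound 4 (0.56 log units; beyond the scatter). Compound 2 gives > 100 ug/mL, which is a limit of the assay and not a number. The size of the step is therefore a lower bound, and this position is the first place in the shared core where a single change is seen to matter, with compound 4 the only compound shown that has a value off the limit: the limit of > 100 ug/mL in this assay, at which 3 of the 4 values shown sit.

This single step cannot separate the departure of benzamido from the arrival of fluoro, so it leaves open which of the two carries the change. As far as these compounds go, a compound with hydrogen, chloro or an amine on the same aromatic carbon would begin to separate them, and it remains open whether fluoro would have a comparable effect with the other groups of the shared core changed.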